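Placing a Chloro Group on a Pyrazole Thiazolidinedione

A few compounds are considered here, and "the series" means these few. Any claim that something is new, unique, unknown or untested is made for them only; others in the source may bear on it.

This short series shares one core, varied at two positions. Compound 1 `CCCN1C(=O)S/C(=C\c2cn(-c3ccccc3)nc2-c2ccc(Cl)cc2)C1=O` was prepared, but in a functional assay on SH-SY5Y cells (Homo sapiens) for inhibition, with stated times of 48 h and 72 h (a lower number here means a stronger inhibitor, a higher number a weaker inhibitor), compound 1 gives "not evaluated" (no result reported), so no single number exists for it. Compound 3 `O=C1S/C(=C\c2cn(-c3ccccc3)nc2-c2ccccc2)C(=O)N1Cc1ccccc1` stands the same way: in this assay compound 3 gives "not evaluated" (no result reported), and so neither compound 1 nor compound 3 can be placed on the scale. For the measured compounds named here, compound 2 `C=CCN1C(=O)S/C(=C\c2cn(-c3ccccc3)nc2-c2ccc(Cl)cc2)C1=O` is the only member with a number: in this assay compound 2 gives 10000 nM, a weak result. Going by the values given here, that is the whole of what is known so far, and it gives no step between two measured compounds to lean on.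

The move of interest goes from compound 3 to compound 4 `O=C1S/C(=C\c2cn(-c3ccccc3)nc2-c2ccc(Cl)cc2)C(=O)N1Cc1ccccc1`, and it is a small one: chloro in place of hydrogen on an aromatic carbon. Everything else in the molecule stays the same. Since compound 3 has no number, the size and direction of this step cannot be read from the data; it is simply unknown whether adding the chloro group helps, hurts or changes nothing beyond the scatter.

The best anchor is therefore compound 2, which shares the 4-chlorophenyl group with compound 4 but differs elsewhere. Compound 4 is expected to land near 8000 nM, within a wide range from 2000 nM to 30000 nM, because compound 2 gives 10000 nM in this assay and nothing in the data suggests a large departure from that.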

Compound 4, half-maximal inhibitory concentration: 8000 nM
Compound 4: middle estimate and measured number agree at the digits printed; low and high end bracket the measured number.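

In this assay the new result gives this series its first real comparison: with the 4-chlorophenyl group held fixed, placing phenyl instead of vinyl on a saturated chain carbon bound to an amide-type nitrogen in a ring gives a 1.3-fold lower number from compound 2 to compound 4 (0.10 log units; within the scatter). This swap on the chain therefore leaves the number within the usual scatter, so this one pair gives no sign that the read-out depends on which of these two groups sits there. Nothing measured here offers an explanation for this result.

As far as these compounds go, the step from phenyl to 4-chlorophenyl cannot be read without a number for compound 3, so the contribution of the chloro group itself remains unknown. Also open, from the compounds shown here alone, is whether a longer chain, an amine or a carboxylic acid at the chain position, or fluoro or methoxy in place of the chloro group, would move the number beyond the scatter in this assay.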